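Chlorine on the phenyl ring of a tetrazole acetamide series

The compounds below may be only part of what the source reports. "The series", "measured", "known", "first", "only" and "open" are said of these compounds alone.

Compound 1 `Cc1cc(NC(=O)Cn2nnc(-c3ccccc3)n2)n(C2CCCCC2)n1` gives 96 nM in an assay on HEK293 cells for activation of Kir3.1/Kir3.2 (Homo sapiens), read by thallium flux (on this read-out lower numbers stand for an effect already at smaller amounts and higher numbers for an effect only at larger amounts of compound), the lowest of the two numbers recorded so far. Its neighbour compound 2 `Cc1cc(NC(=O)Cn2nnc(-c3ccccc3)n2)n(C2CCOCC2)n1` gives 435 nM; the step of a 4.5-fold higher number from compound 1 to compound 2 (0.66 log units; beyond the scatter) concerns the saturated ring on the aromatic nitrogen and nothing else. Compound 3 `Cc1cc(NC(=O)Cn2nnc(-c3cccc(Cl)c3)n2)n(C2CCCCC2)n1` is not yet measured; it differs from compound 1 by chloro in place of hydrogen on an aromatic carbon. Among the measured compounds shown here, no measured step touches the phenyl ring, so the only step in hand, from compound 1 to compound 2, does not bear on this change; it is merely a modest reference for how far a single substitution has moved the numbers here. With nothing pointing either way, the expected step of a 1.1-fold lower number from compound 1 to compound 3 (0.05 log units; within the scatter) is taken as lying within the usual scatter. Compound 3 is therefore estimated at 85 nM, with a range from 30 nM to 260 nM.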

Compound 3, half-maximal effective concentration: 300 nM
Beside the measured number, compound 3's estimate is 3.5-fold (0.55 log units) below it; measured number above the stated range.
By their numbers in this assay, from the lowest: compound 1; then compounds 3 and 2 (each within the scatter of the next).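

The phenyl ring is not a silent position in this assay: 3-chlorophenyl in place of phenyl gives a 3.1-fold higher number from compound 1 to compound 3 (0.49 log units; beyond the scatter) and so moves the number beyond the scatter with the addition of one chlorine atom. Among the compounds shown here, this is the first measured change on this ring, and its direction matches that of the change on the aromatic nitrogen, a 4.5-fold higher number from compound 1 to compound 2 (0.66 log units; beyond the scatter), so neither change has yet given a lower number than compound 1. No available measurement addresses what lies behind the step on the phenyl ring.

Whether this step is specific to chloro remains open, as the compounds shown include no fluoro, methyl or methoxy group on the phenyl ring. Also open, on these data alone, is whether chloro gives a similar step when oxan-4-yl replaces cyclohexyl on the aromatic nitrogen.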